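Para-fluoro on the benzoyl of a weak receptor antagonist

The compounds below may be only part of what the source reports. "The series", "measured", "known", "first", "only" and "open" are said of these compounds alone.

This account concerns three close analogues sharing one core. Compound 1 `N#Cc1c(NCc2ccc(F)cc2)sc2c1CCN(C(=O)c1ccc(F)cc1)C2` is described without any result in a functional assay on Chem-3 cells for antagonist activity at metabotropic glutamate receptor 1 (Homo sapiens), read by fluorescence and calcium flux; a lower number here means a stronger inhibitor, a higher number a weaker inhibitor; for compound 1 the entry there reads "not determined" (no result reported), so no number is available for it. For the measured compounds named here, compound 2 `N#Cc1c(NCc2cccc(F)c2)sc2c1CCN(C(=O)c1ccccc1)C2` is therefore the only compound with a value, and in this assay compound 2 gives 5310 nM, which places it as a weak inhibitor and leaves it without any measured neighbour to compare against. Compound 3 `N#Cc1c(NCc2cccc(F)c2)sc2c1CCN(C(=O)c1ccc(F)cc1)C2` differs from compound 2 by a single change: fluoro in place of hydrogen on an aromatic carbon. Going by the values given here, no step between measured compounds is available to calibrate this change, so the expectation for this assay is a shift of no more than the usual scatter, in no firm direction. On that basis compound 3 is expected to give about 4500 nM, within a range from 1800 nM to 11000 nM, which corresponds to an estimated step of a 1.2-fold lower number from compound 2 to compound 3 (0.07 log units; within the scatter).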

Compound 3, half-maximal inhibitory concentration: 2380 nM
Compound 3: the middle estimate sits 1.9-fold (0.28 log units) above what was measured; the range from low to high includes it.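

In this assay, for the compounds shown here, the change from benzoyl to (4-fluorophenyl)carbonyl gives a 2.2-fold lower number from compound 2 to compound 3 (0.35 log units; beyond the scatter), a modest step that is the first sign that this place, para to a large group, responds to substitution at all. It rests on this single pair: compound 1 also carries the 4-fluorophenyl group but has no number, so no comparison with it can be read. Nothing at hand bears on why fluoro in place of hydrogen lowers the number here.

The compounds shown leave open whether the gain is particular to fluoro or would also appear with chloro, methoxy or an amine in the same place. They also leave open whether the step would hold with another group in place of the 3-fluorobenzyl amine part of compound 3.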